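Octylsulfonamide benzoic acids: styryl analogue awaiting measurement

The compounds below may be only part of what the source reports. "The series", "measured", "known", "first", "only" and "open" are said of these compounds alone.

Measured so far in an assay on mitochondria (strain BALB/c) for inhibition of glycerol-3-phosphate acyltransferase 1, mitochondrial (Mus musculus), read by scintillation counting, with a stated time of 10 min; a higher number here means a weaker inhibitor, a lower number a stronger inhibitor:
compound 1 `CCCCCCCCS(=O)(=O)Nc1cc(-c2ccccc2OC)ccc1C(=O)O` gives 16100 nM
compound 2 `CCCCCCCCS(=O)(=O)Nc1ccc(-c2ccc(O)cc2)cc1C(=O)O` gives 47300 nM

Compound 1 stands lowest of the two numbers in this assay. Its nearest neighbour is compound 2, whose number is higher by a gap beyond the scatter; the two differ in more than one place, so nothing further is drawn from that pair.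

Compound 3 `CCCCCCCCS(=O)(=O)Nc1cc(/C=C/c2ccc(OC)cc2)ccc1C(=O)O` is the next member and is not yet measured in this assay. It is derived from compound 1 by one change: 2-(4-methoxyphenyl)ethenyl in place of 2-methoxyphenyl on an aromatic carbon. The rest of the shared core, the octylsulfonamide and the carboxy group are unchanged.

Going by the values given here, no step between measured compounds informs on this kind of change, so the expectation rests on compound 1 alone. Among the compounds with values here, with compound 1 at 16100 nM and no comparable precedent, no step beyond the scatter is expected in this assay: the estimated step of a 1.3-fold lower number from compound 1 to compound 3 (0.13 log units; within the scatter) is small, with either direction possible. Compound 3 is accordingly expected near 12000 nM, within a range of 3000 nM to 48000 nM.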

Compound 3, half-maximal inhibitory concentration: 38700 nM
Compound 3: the middle estimate sits 3.2-fold (0.51 log units) below what was measured; the measured number falls inside the stated range.
By their numbers in this assay, from the lowest: compound 1; then compounds 3 and 2 (each within the scatter of the next).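

Going by these compounds alone, at the aromatic carbon para to a carboxy group, this assay now gives a first reading of a single change: 2-(4-methoxyphenyl)ethenyl in place of 2-methoxyphenyl brings a 2.4-fold higher number from compound 1 to compound 3 (0.38 log units; beyond the scatter). The position therefore responds to the group it carries, although the step is modest, and compound 3 still gives a finite number at 38700 nM. The change combines two differences, the ethenyl link and the methoxy group's location on the outer ring, and no available measurement accounts for the step or assigns it to either difference.

The two differences remain unseparated: a directly attached 4-methoxyphenyl group and a 2-(2-methoxyphenyl)ethenyl group would each isolate one of them against compound 1 and compound 3. Going by these compounds, it also remains open how far this position accepts other outer-ring substituents, such as an amine or a carboxylic acid in place of the methoxy group, or a saturated ethyl link in place of the ethenyl link.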